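A Trifluoromethoxy Swap at the Limit of a Cytotoxicity Test

A few compounds are considered here, and "the series" means these few. Any claim that something is new, unique, unknown or untested is made for them only; others in the source may bear on it.

Compound 1 (`CCc1ccc(-c2nc3c(c(C)nn3-c3ccccc3)c(-c3ccccc3Cl)c2C#N)cc1`), compound 2 (`CCc1ccc(-c2nc3c(c(C)nn3-c3ccccc3)c(-c3ccccc3F)c2C#N)cc1`) and compound 3 (`CCc1ccc(-c2nc3c(c(C)nn3-c3ccccc3)c(-c3ccccc3C(F)(F)F)c2C#N)cc1`) share one core and differ only in a single group on an aromatic carbon. In an ADME assay on BJ cells (Homo sapiens) for cytotoxicity, with a stated time of 72 h (on this read-out higher numbers stand for an effect only at larger amounts of compound and lower numbers for an effect already at smaller amounts), compound 1 gives > 20000 nM as a limit, not a number. Compound 2 gives > 20000 nM as a limit too. Compound 3 gives > 20000 nM and is likewise only a limit, so it has no exact place among the others. The whole set shows the limit of > 20000 nM in this assay, at which 3 of the 3 values shown sit, and nothing more precise.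

Compound 4 (`CCc1ccc(-c2nc3c(c(C)nn3-c3ccccc3)c(-c3ccccc3OC(F)(F)F)c2C#N)cc1`) has not yet been measured. It differs from compound 3 by one change, trifluoromethoxy in place of trifluoromethyl on an aromatic carbon and this sits on an aromatic carbon ortho to a large group.

Among the compounds with values here, three measured steps bear on this: a step that the two limits leave unreadable from compound 1 to compound 2 with fluoro in place of chloro, a step that the two limits leave unreadable from compound 1 to compound 3 with trifluoromethyl in place of chloro, and a step that the two limits leave unreadable from compound 2 to compound 3 with trifluoromethyl in place of fluoro. None has a readable size, yet no swap at this place has brought a value down from the limit. What is expected in this assay is a step that the limit leaves unreadable from compound 3 to compound 4 with no direction beyond the scatter. For compound 4 the estimated value is 25000 nM with an expected range from 12000 nM to 50000 nM as its ends.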

Compound 4, half-maximal effective concentration: > 20000 nM
Compound 4 ended at the assay's limit; the forecaster's own chance of this, stated with the estimate: 90%; the middle value does not contradict the limit.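

Within the data shown here, no step linking compound 4 with compound 1, compound 2 or compound 3 can be read in this assay, because all four compounds stop at a limit of the assay, not at a number: the limit of > 20000 nM in this assay, at which 4 of the 4 values shown sit. The compounds shown leave open at what amount, if any, each would affect the cells, and whether swapping this one group changes that amount.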